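Naphthalen-1-yl for phenethyl on the shared core

This account rests on a few compounds, and the source may have more. Where it says the series, first, only, none or still open, it means among the compounds named here.

Compound 1 `COc1ccc(F)cc1CNCCCNc1ccnc2cc(CCc3ccccc3)ccc12` and compound 2 `COc1cccc(CNCCCNc2ccnc3cc(Cc4ccc(C#N)cc4)ccc23)c1O` share the same diamine linker to the core and have been measured in a physicochemical assay for acid dissociation. In this assay compound 1 gives 9.47, and compound 2 gives 9.47, so the two stand level at the digits shown, within the scatter of the method. Going by the values given here, no step between a pair differing in a single place is available, so compound 1 is placed only by its own value and the level reading of compound 2.

Compound 3 `COc1ccc(F)cc1CNCCCNc1ccnc2cc(-c3cccc4ccccc34)ccc12` is the next member to be measured in this assay. Relative to compound 1 it carries the change (naphthalen-1-yl in place of phenethyl on an aromatic carbon). Both the group that leaves and the group that enters are carbon-only aromatic pieces with no hydrogen-bond donors or acceptors and no net charge, and the amines of the linker are untouched.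

On that basis the step of a number 0.02 log units lower from compound 1 to compound 3 (within the scatter) is expected to be none beyond the scatter, in either direction. Compound 3 is therefore estimated at 9.45 in this assay, with a range from 9.1 to 9.8.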

Compound 3, acid dissociation constant: 9.47
Estimate against measurement, compound 3: 0.02 log units below, and the stated range covers the measured number.
By their numbers in this assay, from the lowest: compounds 1, 2 and 3 (each within the scatter of the next).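

In this assay, going by these compounds alone, the exchange of phenethyl for naphthalen-1-yl on this aromatic carbon, meta to a fused ring and para to a fused ring, gives the first step between compounds that differ in one place, and it reads no change at the digits printed from compound 1 to compound 3 (within the scatter) in this pair. The earlier compounds shown here could not show this, since compound 2 differs from compound 1 in more than one place and its level reading says nothing about this position alone. Here a group of 8 heavy atoms with one six-membered aromatic ring gives way to one of 10 heavy atoms with 2 such rings, and the read-out does not separate the two, although no measurement on these compounds offers a reason for that.

As far as these compounds go, both groups compared at this position are built of carbon only, so the reading of this assay with an amine or a carboxylic acid on the same aromatic carbon stays open. Also open, from the compounds shown here alone, is how the read-out responds to a longer chain between the two amines of the linker, a part of the molecule that this step leaves untouched.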